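Swapping a Distal Aryl Ring for Bromine

The compounds below may be only part of what the source reports. "The series", "measured", "known", "first", "only" and "open" are said of these compounds alone.

Compound 2 `CC[C@@H](Nc1c(C#N)c(-c2ccc(-c3cccc(C)c3)cc2)nc2cnccc12)C(N)=O` sits at the top of a small set of three in a physicochemical assay for lipophilicity, read by HPLC, at pH 7.5 (a lower number here means a more polar compound, a higher number a more lipophilic compound), giving 3. Compound 3 `CCOc1ccccc1-c1ccc(-c2nc3cnccc3c(N[C@H](CC)C(N)=O)c2C#N)cc1` gives 3 in this assay, and the two are level, as no change at the digits printed from compound 2 to compound 3 (within the scatter) shows. Compound 1 `CC[C@@H](Nc1c(C#N)c(-c2ccc(-c3ccccc3F)cc2)nc2cnccc12)C(N)=O` gives 2.7 in this assay, and the steps of a number 0.30 log units higher from compound 1 to compound 2 (within the scatter) and a number 0.30 log units higher from compound 1 to compound 3 (within the scatter) are both small.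

Compound 4 `CC[C@@H](Nc1c(C#N)c(-c2ccc(Br)cc2)nc2cnccc12)C(N)=O` is not yet measured. Relative to compound 2 the change is bromo in place of 3-methylphenyl on an aromatic carbon. All three measured steps only vary a substituent on the distal ring while keeping that ring; none removes the ring itself, so they bear only loosely on this change and suggest nothing about its size. The change takes away a whole aromatic ring and its methyl and leaves a single bromine, so a clear drop in this assay is expected, of about a number 1.20 log units lower from compound 2 to compound 4 (beyond the scatter). Compound 4 is therefore estimated to give 1.8 in this assay, within a range from 1.3 to 2.4.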

Compound 4, distribution coefficient: 2.2
Estimate against measurement, compound 4: 0.40 log units below, and the stated range covers the measured number.
By their numbers in this assay, from the lowest: compound 4; then compounds 1, 2 and 3 (each within the scatter of the next).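

Replacing the whole distal ring moves the number beyond the scatter in this assay: bromo in place of 3-methylphenyl gives a number 0.80 log units lower from compound 2 to compound 4 (beyond the scatter) and bromo in place of 2-ethoxyphenyl gives a number 0.80 log units lower from compound 3 to compound 4 (beyond the scatter) and bromo in place of 2-fluorophenyl gives a number 0.50 log units lower from compound 1 to compound 4 (beyond the scatter). On this aromatic carbon, then, among these four compounds, the presence of the ring counts for more than the changes to its substituents, all of which stayed within the scatter. No measured evidence is at hand to explain the drop.

The compounds shown leave open how much of the step comes from losing the ring and how much from bromine itself. A smaller group at this carbon, such as an amine, a carboxylic acid or a longer chain, would help separate the two.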